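Swapping the tetrazole-bearing chain for a carboxylic acid chain

The source may report more compounds than this note shows. Statements on the series, on what has been measured and on what is new or still open speak of the compounds shown alone.

Measured compounds:
Compound 1 `CCCc1c(COc2ccc(C(=O)CCc3nnn[nH]3)cc2)ccc(C(C)=O)c1O`: 10.1 mg/kg
Compound 2 `CCCc1c(COc2ccc(C(=O)C(C)Cc3nnn[nH]3)cc2)ccc(C(C)=O)c1O`: 9.2 mg/kg
Compound 3 `CCCc1c(COc2ccc(C(=O)C(C)(C)Cc3nnn[nH]3)cc2)ccc(C(C)=O)c1O`: 10.8 mg/kg

All three compounds share one core and were tested in an in vivo functional assay on the whole organism (Rattus norvegicus) with cysteinyl leukotriene receptor (Homo sapiens) as the target; on this read-out lower numbers stand for an effect already at smaller amounts and higher numbers for an effect only at larger amounts of compound. Compound 3 carries the highest of the three numbers, yet the steps of a 1.1-fold higher number from compound 1 to compound 3 (0.03 log units; within the scatter) and a 1.2-fold higher number from compound 2 to compound 3 (0.07 log units; within the scatter) both lie within the scatter, as does the step of a 1.1-fold lower number from compound 1 to compound 2 (0.04 log units; within the scatter). On this assay the three compounds are therefore indistinguishable: adding one or two methyl groups on the chain between the carbonyl and the tetrazole ring changed nothing that can be trusted.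

Compound 4 `CCCc1c(COc2ccc(C(=O)CCCC(=O)O)cc2)ccc(C(C)=O)c1O` has not yet been measured. It differs from compound 3 as follows: 3-carboxypropyl in place of 1-((1H-tetrazol-5-yl)methyl)-1-methylethyl on a carbonyl carbon. None of the three measured steps bears on this exchange. Each of them only added a methyl group to the same chain and kept the tetrazole ring in place, whereas here the ring itself is removed and an open acid chain takes its position on the carbonyl carbon. The measured data give no guide to the direction of the effect, so the expectation must be wide. Compound 4 is expected to give an estimate of 12 mg/kg in this assay, within a range from 4 mg/kg to 40 mg/kg. This estimate corresponds to an expected step of a 1.1-fold higher number from compound 3 to compound 4 (0.05 log units; within the scatter).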

Compound 4, dose for half-maximal effect: 9.5 mg/kg
Compound 4: the middle estimate sits 1.3-fold (0.10 log units) above what was measured; measured number inside the range.
By their numbers in this assay, from the lowest: compounds 2, 4, 1 and 3 (each within the scatter of the next).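

In this assay, the open 3-carboxypropyl chain takes the place of the tetrazole-bearing chain on the carbonyl carbon without any change that can be trusted: the exchange gives a 1.1-fold lower number from compound 3 to compound 4 (0.06 log units; within the scatter), a 1.0-fold higher number from compound 2 to compound 4 (0.01 log units; within the scatter) and a 1.1-fold lower number from compound 1 to compound 4 (0.03 log units; within the scatter). The earlier compounds varied only methyl groups on the chain and always kept the tetrazole ring, whereas these steps show that, among these four compounds, the ring itself can be absent and the dose needed stays within the usual scatter. No measurement here explains why a tetrazole ring and a carboxylic acid at the end of the chain read alike in this whole-animal test.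

Still open, on these data alone, is whether the end of the chain matters at all, which a plain propyl chain with neither tetrazole nor carboxylic acid, or an amine in that place, would test. Also open, as far as these compounds go, is how a longer chain ending in the carboxylic acid would read, or an acid chain carrying the methyl groups seen in compound 2 and compound 3.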